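A Pyridine Nitrogen Enters the Benzyl Group of Compound 1

A few compounds are considered here, and "the series" means these few. Any claim that something is new, unique, unknown or untested is made for them only; others in the source may bear on it.

compound 1 `COc1ccc2[nH]c3c(c2c1)CCNC31CCN(Cc2ccccc2)CC1`: 12600 nM
compound 2 `COc1ccc2[nH]c3c(c2c1)CCNC31CCN(C(C)c2ccccc2)CC1`: 20000 nM

Both were tested in an assay on FRT cells for positive allosteric modulation of Cystic fibrosis transmembrane conductance regulator variant N1303K (Homo sapiens), in the presence of a further agent that is not named here; on this read-out lower numbers stand for an effect already at smaller amounts and higher numbers for an effect only at larger amounts of compound. Compound 1 gives 12600 nM, the lowest of the two numbers; compound 2 sits at 20000 nM. Among the measured compounds shown here, the only measured step, a 1.6-fold higher number from compound 1 to compound 2 (0.20 log units; within the scatter), concerns a different place and so does not bear on the change considered here.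

Compound 3 `COc1ccc2[nH]c3c(c2c1)CCNC31CCN(Cc2cccnc2)CC1` differs from compound 1 by pyridin-3-yl in place of phenyl on a saturated chain carbon bound to an amine nitrogen in a ring. For the measured compounds named here, no measured step informs this change, so no shift beyond the scatter is expected. Compound 3 is therefore estimated at 12000 nM, with a range from 4000 nM to 36000 nM. This corresponds to an expected step of a 1.1-fold lower number from compound 1 to compound 3 (0.02 log units; within the scatter).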

Compound 3, half-maximal effective concentration: 17000 nM
The estimate for compound 3 lay 1.4-fold (0.15 log units) below the measured number, within the range that was stated.
By their numbers in this assay, from the lowest: compounds 1, 3 and 2 (each within the scatter of the next).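

In this assay, pyridin-3-yl in place of phenyl on a saturated chain carbon bound to an amine nitrogen in a ring gives a 1.3-fold higher number from compound 1 to compound 3 (0.13 log units; within the scatter), so this read-out does not distinguish the two rings at this position. (Pyridin-3-yl)methyl in place of 1-phenylethyl on an amine nitrogen in a ring gives a 1.2-fold lower number from compound 2 to compound 3 (0.07 log units; within the scatter), which likewise separates nothing. No evidence bears on this result. On these data alone, whether pyridin-2-yl, pyridin-4-yl or a phenyl ring carrying a carboxylic acid would give a step beyond the scatter remains open.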